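The compounds below may be only part of what the source reports. "The series", "measured", "known", "first", "only" and "open" are said of these compounds alone.

Measured compounds:
compound 1 `CN(C)C(=O)c1ccncc1Nc1cc(-c2ccc3ccn(C)c3c2)c2nccnc2c1` — 499 nM
compound 2 `Cn1ccc2ccc(-c3cc(Nc4cnccc4C(=O)NCc4cncnc4)cc4nccnc34)cc21` — 106 nM
compound 3 `Cn1cc(CNC(=O)c2ccncc2Nc2cc(-c3ccc4ccn(C)c4c3)c3nccnc3c2)cn1` — 159 nM

All three were read in an assay for inhibition of 6-phosphofructo-2-kinase/fructose-2,6-bisphosphatase 3 (Homo sapiens), read by ADP-Glo, with a stated time of 2 h; a lower number here means a stronger inhibitor, a higher number a weaker inhibitor. Compound 3 gives the second highest of the three numbers; its nearest neighbour is compound 2, and the two lie within the scatter of each other, while the step from compound 1 is larger: a 3.1-fold lower number from compound 1 to compound 3 (0.50 log units; beyond the scatter). The parallel step a 4.7-fold lower number from compound 1 to compound 2 (0.67 log units; beyond the scatter) shows the same direction, and the comparison a 1.5-fold higher number from compound 2 to compound 3 (0.18 log units; within the scatter) shows that the two amide substituents on a saturated chain carbon are indistinguishable on these numbers.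

Compound 4 `Cn1ccc2ccc(-c3cc(Nc4cnccc4C(=O)NC4CCNC(=O)C4)cc4nccnc34)cc21` is the next compound in this series. Its difference from compound 3 is 2-oxopiperidin-4-yl in place of (1-methyl-1H-pyrazol-4-yl)methyl on an amide-type nitrogen. Going by the values given here, no measured step replaces a ring-bearing methyl chain with a non-aromatic ring on the amide nitrogen, so only indirect guidance exists: the two steps from compound 1 show that enlarging the dimethylamide lowers the number modestly, and the step from compound 2 to compound 3 shows little sensitivity to which ring is carried there. Compound 4 is therefore expected to stay near compound 3, with a step of a 1.4-fold higher number from compound 3 to compound 4 (0.14 log units; within the scatter) in this assay, and its estimated value is 220 nM, with a range from 70 nM to 700 nM.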

Compound 4, half-maximal inhibitory concentration: 69 nM
Beside the measured number, compound 4's estimate is 3.2-fold (0.50 log units) above it, outside the stated range (below it).
By their numbers in this assay, from the lowest: compounds 4, 2 and 3 (each within the scatter of the next, the first and the last beyond it); then compound 1.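

On the amide-type nitrogen, an aromatic ring carried on a methyl chain turns out not to be required in this assay: the non-aromatic 2-oxopiperidin-4-yl, attached directly, gives a 2.3-fold lower number from compound 3 to compound 4 (0.36 log units; beyond the scatter), while a 1.5-fold lower number from compound 2 to compound 4 (0.19 log units; within the scatter) leaves it indistinguishable from the pyrimidine-bearing amide. The position is therefore sensitive to the choice of group in a way the earlier pyrimidine and pyrazole pair did not reveal, and replacing dimethylamino on the carbonyl carbon with (2-oxopiperidin-4-yl)amino gives a 7.2-fold lower number from compound 1 to compound 4 (0.86 log units; beyond the scatter), in the same direction as the other two replacements of that group. Nothing given here explains the gain, and the change from the pyrazole-bearing group alters the ring, the chain and the hydrogen-bond donor count together, so these features cannot be told apart.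

The compounds shown leave open whether the ring carbonyl or the ring hydrogen-bond donor of the 2-oxopiperidin-4-yl group matters, which a plain piperidin-4-yl amine, a cyclohexyl ring or a 1-methyl-2-oxopiperidin-4-yl group could test. They also leave open whether the direct attachment matters, which a (2-oxopiperidin-4-yl)methyl group on the same nitrogen could test.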